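The source may report more compounds than this note shows. Statements on the series, on what has been measured and on what is new or still open speak of the compounds shown alone.

Working notes on the series, a functional assay on HepG2 cells (Homo sapiens) for cytotoxicity, read by MTT assay, with a stated time of 72 h; on this read-out higher numbers stand for weaker inhibition and lower numbers for stronger inhibition.

Three compounds of the shared core carry different amide substituents. Compound 1 `CN1[C@@H]2c3[nH]c4ccccc4c3C[C@H]1[C@H](C#N)N1[C@@H](CNC(=O)c3ccc(Cl)cc3)c3[nH]c4ccccc4c3C[C@@H]21` gives 350 nM. Compound 2 `CCc1ccc(C(=O)NC[C@H]2c3[nH]c4ccccc4c3C[C@H]3[C@H]4c5[nH]c6ccccc6c5C[C@@H]([C@H](C#N)N23)N4C)cc1` gives 570 nM, the highest number of the three; its nearest neighbour is compound 3 `CN1[C@@H]2c3[nH]c4ccccc4c3C[C@H]1[C@H](C#N)N1[C@@H](CNC(=O)/C=C/c3cccc(C(F)(F)F)c3)c3[nH]c4ccccc4c3C[C@@H]21` with 540 nM, and its furthest is compound 1, yet both separations, a 1.6-fold higher number from compound 1 to compound 2 (0.21 log units; within the scatter) and a 1.1-fold lower number from compound 2 to compound 3 (0.02 log units; within the scatter), sit within the scatter, so no order among the three can be claimed.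

The next compound, compound 4 `CN1[C@@H]2c3[nH]c4ccccc4c3C[C@H]1[C@H](C#N)N1[C@@H](CNC(=O)/C=C/c3ccccc3)c3[nH]c4ccccc4c3C[C@@H]21`, differs from compound 2 as follows: 2-phenylethenyl in place of 4-ethylphenyl on a carbonyl carbon. Among the compounds with values here, the closest precedent is the step from the 4-ethylphenyl amide to the trifluoromethyl-bearing styryl amide, a 1.1-fold lower number from compound 2 to compound 3 (0.02 log units; within the scatter), and the related step from the chloro analogue, a 1.5-fold higher number from compound 1 to compound 3 (0.19 log units; within the scatter); both replace an aryl group on the carbonyl carbon with an ethenyl-linked aryl group and both stay within the scatter. The swap of one ring substituent for another, a 1.6-fold higher number from compound 1 to compound 2 (0.21 log units; within the scatter), is likewise within the scatter. On this basis the move to compound 4 is expected to be a 1.0-fold lower number from compound 2 to compound 4 (0.02 log units; within the scatter), that is, no change beyond the scatter in this assay. Compound 4 is therefore estimated at 550 nM, with a range from 280 nM to 1100 nM, pending measurement.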

Compound 4, half-maximal inhibitory concentration: 470 nM
For compound 4 the middle estimate is 1.2-fold (0.07 log units) above the measured one, within the range that was stated.
By their numbers in this assay, from the lowest: compounds 1, 4, 3 and 2 (each within the scatter of the next).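

In this assay, the place on the carbonyl carbon whose other neighbour is the amide-type nitrogen accepts 2-phenylethenyl in place of 4-ethylphenyl, a swap that adds a double bond outside the aromatic ring while the heavy-atom count stays equal, and the step stays within the scatter: a 1.2-fold lower number from compound 2 to compound 4 (0.08 log units; within the scatter); the step from the chloro analogue, a 1.3-fold higher number from compound 1 to compound 4 (0.13 log units; within the scatter), also stays within the scatter. Within the data shown here, the new compound also isolates the ring substituent of the ethenyl-linked aryl group for the first time, and hydrogen in place of trifluoromethyl on an aromatic carbon gives a 1.1-fold lower number from compound 3 to compound 4 (0.06 log units; within the scatter), so across the four compounds neither this substituent nor the ethenyl link separates from the scatter. No measurement on hand gives a reason for these numbers or bears on what lies behind them.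

As far as these compounds go, all four amides carry a hydrocarbon-linked or directly attached aryl group with no hydrogen-bond donor or acceptor in the part that varies, so the effect of an amine or a carboxylic acid on the aromatic ring remains open. From the compounds shown here alone, whether a longer chain in place of the ethenyl link would give a step beyond the scatter in this assay also remains open.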